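A Pyridine Amide Follows a Dichlorophenyl Lead

The source may hold more compounds than are shown below. What is called first, only, known or untested is meant among the compounds shown, and "the series" means these compounds.

Compound 1 `Cc1ccc(C(=O)Nc2cc(-c3ccccc3)nn2-c2ccccc2)cc1C` and compound 2 `O=C(Nc1cc(-c2ccccc2)nn1-c1ccccc1)c1ccc(Cl)c(Cl)c1` share one core and differ only in the group on the carbonyl carbon. In an assay on HEK293 cells for displacement of a labelled ligand from metabotropic glutamate receptor 5 (Rattus norvegicus) (a lower number here means a stronger inhibitor, a higher number a weaker inhibitor), compound 1 gives 430 nM, while compound 2 gives 160 nM, the lowest of the two numbers; the step between them is a 2.7-fold lower number from compound 1 to compound 2 (0.43 log units; beyond the scatter). Compound 3 `Cc1ccc(C(=O)Nc2cc(-c3ccccc3)nn2-c2ccccc2)cn1` carries the change (6-methylpyridin-3-yl in place of 3,4-dichlorophenyl on a carbonyl carbon). Among the compounds with values here, only the step from compound 1 to compound 2 bears on this, and it favoured the dichlorophenyl. For compound 3 a modestly higher number is therefore expected, a 3.1-fold higher number from compound 2 to compound 3 (0.49 log units; beyond the scatter). Compound 3 is estimated at 500 nM, with a range from 150 nM to 1700 nM.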

Compound 3, inhibition constant: 3480 nM
Compound 3: middle estimate off by 7.0-fold (0.84 log units), on the low side, outside the stated range (above it).
By their numbers in this assay, from the lowest: compound 2; then compound 1; then compound 3.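

Swapping 3,4-dichlorophenyl for 6-methylpyridin-3-yl on the carbonyl carbon gives a 22-fold higher number from compound 2 to compound 3 (1.34 log units; beyond the scatter), so this position responds far more strongly than the first step suggested. The same entering group also compares poorly with 3,4-dimethylphenyl, with an 8.1-fold higher number from compound 1 to compound 3 (0.91 log units; beyond the scatter), so the loss does not depend on the chlorine atoms being removed. Nothing available explains why the number rises.

The compounds shown leave open whether the ring nitrogen or the lost substituent matters more. They also leave open how a phenyl ring carrying a single chlorine, or an amine, would behave here.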